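This account rests on a few compounds, and the source may have more. Where it says the series, first, only, none or still open, it means among the compounds named here.

Of the compounds shown here, three built on one shared core have been tested in an ADME assay on PA-1 cells (Homo sapiens) for cytotoxicity, read by MTT assay, with a stated time of 72 h; a higher number here means a weaker inhibitor, a lower number a stronger inhibitor. Compound 1, `COc1ccc(C2=C(c3cc(OC)c(OC)c(OC)c3)C(=O)CC2O[SiH2]C(C)(C)C)cc1`, reaches only a limit of the assay in this assay, > 100 ug/mL. Compound 2, `C=CCOc1cc(C2=C(c3cc(OC)c(OC)c(OC)c3)C(=O)C(O)C2)ccc1OC`, likewise reaches only a limit, > 100 ug/mL. Compound 3, `COc1ccc(OC)c(C2=C(c3cc(OC)c(OC)c(OC)c3)C(=O)CC2O[SiH2]C(C)(C)C)c1`, gives a number, 17 ug/mL. The single measured step, an at least 5.8-fold lower number from compound 1 to compound 3 (0.76 log units; beyond the scatter), is the only change among these three that stands out from the scatter. Compound 2 thus sits at the limit of > 100 ug/mL in this assay, at which 2 of the 3 values shown sit, with no number of its own to compare against.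

Compound 4 is `COc1ccc(C2=C(c3cc(OC)c(OC)c(OC)c3)C(=O)C(O)C2)cc1NC(=O)c1ccccc1`. It differs from compound 2 by benzamido in place of allyloxy on an aromatic carbon. Among the compounds with values here, no measured step bears directly on this exchange: the step from compound 1 to compound 3 concerns a different kind of change, so it offers no guide to size or direction here. The step of an at least 1.2-fold lower number from compound 2 to compound 4 (0.09 log units; that floor lies within the scatter) is therefore expected to be small, with a wide range, and another limit is the likeliest outcome. Compound 4 is expected to give about 80 ug/mL, somewhere between 20 ug/mL and 300 ug/mL.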

Compound 4, half-maximal inhibitory concentration: > 100 ug/mL
Compound 4: only a limit was reported; the forecaster's own chance of this, stated with the estimate: 60%; at least 1.2-fold (0.09 log units) between middle value and limit.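

In this assay compound 4 gives only a limit, > 100 ug/mL. Compound 2 gives a limit too, so the step from compound 2 to compound 4 cannot be read, and both compounds rest at the same mark: the limit of > 100 ug/mL in this assay, at which 3 of the 4 values shown sit. On these data alone, how far benzamido and allyloxy differ in this read-out stays open.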